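The compounds below may be only part of what the source reports. "The series", "measured", "known", "first", "only" and "open" are said of these compounds alone.

Compound 1 `O=c1nc(NO)c(F)cn1[C@@H]1C[C@@H](O)[C@H](CO)O1` was tested in an ADME assay on HepG2 cells (Homo sapiens) for cytotoxicity, read by MTT assay, with a stated time of 3 days (a lower number here means that less compound is tolerated, a higher number that more compound is tolerated), where compound 1 gives 920000 nM. That is the lowest of the two numbers obtained, but the nearest, compound 2 `[N-]=[N+]=N[C@@H]1C[C@@H](n2ccc(NO)nc2=O)O[C@H]1CO`, lies within the usual scatter: in this assay compound 2 gives 1160000 nM. Compound 3 `Cc1cn([C@H]2OC[C@H](O)[C@H](O)[C@H]2O)c(=O)nc1N` reaches only a limit of this assay, with compound 3 giving > 2000000 nM. The set therefore contains (the limit of > 2000000 nM in this assay, at which 1 of the 3 values shown sits).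

The unmeasured compound 4 `Cc1cn([C@@H]2C[C@@H](O)[C@H](CO)O2)c(=O)nc1NO` differs from compound 1 in one place: methyl in place of fluoro on an aromatic carbon. For the measured compounds named here, no step between two measured compounds is available to anchor this change, so the expectation rests on the values themselves. Since the two numbers for compound 1 and compound 2 sit within the scatter of one another, the step for this exchange is expected to be small, in no firm direction, and not clearly beyond the scatter. The expected step is a 1.1-fold higher number from compound 1 to compound 4 (0.04 log units; within the scatter). In this assay compound 4 is therefore estimated at 1000000 nM, with a range from 400000 nM to 2500000 nM.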

Compound 4, half-maximal cytotoxic concentration: 490000 nM
The estimate for compound 4 lay 2.0-fold (0.31 log units) above the measured number; measured number inside the range.
By their numbers in this assay, from the lowest: compounds 4, 1 and 2 (each within the scatter of the next, the first and the last beyond it). At a limit, above all of these: compound 3.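

In this assay, for the compounds shown here, the exchange of fluoro for methyl on this aromatic carbon, ortho to the hydroxyamino group, supplies the first step in the set that can be read at a single place: a 1.9-fold lower number from compound 1 to compound 4 (0.27 log units; within the scatter). Compound 1 and compound 4 therefore cannot be ordered, and at this position, on this core, the two groups cannot be told apart in this assay. Nothing measured here bears on what lies behind this step.

From the compounds shown here alone, what an ethyl chain, a chlorine atom or an amine on this same aromatic carbon would give in this assay remains open. Going by these compounds, it is also open whether the exchange of fluoro for methyl would give a step of similar size on the core of compound 2.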